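The source may report more compounds than this note shows. Statements on the series, on what has been measured and on what is new or still open speak of the compounds shown alone.

Measured so far in a functional assay on HCT-116 cells (Homo sapiens) for antiproliferative activity, read by MTT assay, with a stated time of 72 h; on this read-out higher numbers stand for weaker inhibition and lower numbers for stronger inhibition:
compound 1 `O=C1O/C(=C\Cn2cc(-c3ccc(Br)cc3)nn2)C(OCc2ccccc2)=C1OCc1ccccc1`: > 100000 nM, a limit of the assay rather than a number.
compound 2 `CCCCCc1ccc(-c2cn(C[C@H](O)[C@H]3OC(=O)C(OCc4ccccc4)=C3OCc3ccccc3)nn2)cc1`: 13800 nM.
compound 3 `O=C1O/C(=C\Cn2cc(-c3cccc(O)c3)nn2)C(OCc2ccccc2)=C1OCc1ccccc1`: 63600 nM.

Compound 2 gives the lowest of the two numbers, with compound 3 beyond the scatter above it. Compound 1 returned only a limit (the limit of > 100000 nM in this assay, at which 1 of the 3 values shown sits). For the measured compounds named here, the single neighbouring step, an at least 1.5-fold lower number from compound 1 to compound 3 (0.19 log units; that floor lies within the scatter), has a floor within the scatter; it exchanges one aryl for another on an aromatic carbon, whereas the change followed here removes the aryl altogether. Compound 4 `Cc1ccc(S(=O)(=O)NCc2cn(C[C@H](O)[C@H]3OC(=O)C(OCc4ccccc4)=C3OCc3ccccc3)nn2)cc1` differs from compound 2 by (((4-methylphenyl)sulfonyl)amino)methyl in place of 4-pentylphenyl on an aromatic carbon. Going by the values given here, no measured step covers this exchange, so only the spread of the series guides it: a move back toward the weaker numbers is expected, a 2.9-fold higher number from compound 2 to compound 4 (0.46 log units; beyond the scatter). Compound 4 is accordingly estimated at 40000 nM, between 12000 nM and 120000 nM.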

Compound 4, half-maximal inhibitory concentration: 13100 nM
For compound 4 the middle estimate is 3.1-fold (0.48 log units) above the measured one; low and high end bracket the measured number.
By their numbers in this assay, from the lowest: compounds 4 and 2 (each within the scatter of the next); then compound 3. At a limit, above all of these: compound 1.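

On this aromatic carbon of the five-membered aromatic ring with 3 nitrogen, the two groups read alike in this assay: a 1.1-fold lower number from compound 2 to compound 4 (0.02 log units; within the scatter). An aryl bonded directly to that carbon is therefore not required for the number of compound 2, and a group with hydrogen-bond donor and acceptors gives the same reading as an all-carbon one. Nothing at hand gives a measured reason for this match.

Open, going by these compounds, is whether a carboxylic acid or a short alkyl chain on this carbon would read the same. On these data alone, whether the match holds on the other cores also remains open.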